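The source may report more compounds than this note shows. Statements on the series, on what has been measured and on what is new or still open speak of the compounds shown alone.

Compound 3 `CCCCCCCCCCCCCCNNC(=O)COC` was tested in a functional assay on K562 cells (Homo sapiens) for antiproliferative activity, read by resazurin assay, with a stated time of 72 h (a lower number here means a stronger inhibitor of growth, a higher number a weaker inhibitor of growth), where compound 3 gives 66200 nM. For comparison, compound 1 `CCCCCCCCCCCCCCN(NC(=O)COC)C(=O)OC(C)(C)C` gives 40900 nM in this assay, and compound 2 `CCCCCCCCCCN(NC(=O)COC)C(=O)OC(C)(C)C` gives 40600 nM. The difference a 1.6-fold higher number from compound 1 to compound 3 (0.21 log units; within the scatter) lies within the scatter, and the gap between compound 3 and compound 2 is of the same size and likewise within the scatter, so the three numbers cannot be ranked against one another.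

Compound 4 `CCCCCCCCCCNNC(=O)COC` has not yet been measured. It differs from compound 3 in one place: hydrogen in place of butyl on a saturated chain carbon, ten or more bonds along the chain from an amine nitrogen. The same change has been measured once before, between the two compounds that carry a tert-butoxycarbonyl group on the amine nitrogen, where a 1.0-fold lower number from compound 1 to compound 2 (0.00 log units; within the scatter) was found; that step moved the number not at all. Nothing among the three measured compounds suggests that the removal of butyl from the chain should read differently when the amine nitrogen carries hydrogen instead. On this basis the step of a 1.0-fold lower number from compound 3 to compound 4 (0.00 log units; within the scatter) is expected to remain within the scatter, with no direction to it. Compound 4 is therefore estimated at 66000 nM in this assay, within a range from 30000 nM to 150000 nM.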

Compound 4, concentration for 50% growth inhibition: 167000 nM
Beside the measured number, compound 4's estimate is 2.5-fold (0.40 log units) below it; measured number above the stated range.
By their numbers in this assay, from the lowest: compounds 2, 1 and 3 (each within the scatter of the next); then compound 4.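

In this assay, hydrogen in place of butyl on a saturated chain carbon, ten or more bonds along the chain from an amine nitrogen, now moves the number beyond the scatter, a 2.5-fold higher number from compound 3 to compound 4 (0.40 log units; beyond the scatter), yet this step does not differ firmly from the same change on the core that carries tert-butoxycarbonyl: the same change on two cores in this assay, a 1.0-fold lower number (0.00 log units; within the scatter) from compound 1 to compound 2 and a 2.5-fold higher number (0.40 log units; beyond the scatter) from compound 3 to compound 4, 2.5-fold (0.41 log units) apart, within the scatter of two such steps. Removal of tert-butoxycarbonyl also now gives a step beyond the scatter on the shorter chain, a 4.1-fold higher number from compound 2 to compound 4 (0.61 log units; beyond the scatter), and again the gap to the same change on the longer chain does not hold up: the same change on two cores in this assay, a 1.6-fold higher number (0.21 log units; within the scatter) from compound 1 to compound 3 and a 4.1-fold higher number (0.61 log units; beyond the scatter) from compound 2 to compound 4, 2.5-fold (0.41 log units) apart, within the scatter of two such steps. Taken together, the two changes hint that each may matter only in the absence of the other, but these four compounds cannot establish that.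

The compounds shown cover only two chain lengths, so it remains open whether a still shorter chain would raise the number further or a longer chain would lower it. On these data alone, it is also open whether an acetyl group on the amine nitrogen, or a carboxylic acid at the end of the chain, would read as tert-butoxycarbonyl does here.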